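A fluorine added where three compounds sit at a limit

The source may hold more compounds than are shown below. What is called first, only, known or untested is meant among the compounds shown, and "the series" means these compounds.

Compound 1 `O=C(O)c1cccc(-c2ccc(/C=C3\S/C(=N\c4ccc(F)cc4)N(c4ccc(F)cc4)C3=O)o2)c1` and compound 2 `O=C(O)c1cccc(-c2ccc(/C=C3\S/C(=N\c4ccccc4)N(c4ccc(F)cc4)C3=O)o2)c1` share one core, while compound 3 `O=C(O)c1cccc(-c2ccc(/C=C3\S/C(=N\c4ccc(Cl)cc4)N(c4ccccn4)C3=O)o2)c1` stands on a different one; the difference between the two cores is not broken down here. In an ADME assay on Vero cells (Chlorocebus sabaeus) for cytotoxicity (a higher number here means that more compound is tolerated, a lower number that less compound is tolerated), compound 1 gives only a limit, > 200000 nM. Compound 2 likewise reaches only a limit in this assay, > 200000 nM. Compound 3 too gives only a limit in this assay, > 200000 nM. From compound 2 to compound 1 the change is fluoro in place of hydrogen on an aromatic carbon, and the step is a step that the two limits leave unreadable from compound 2 to compound 1 because of the limit of > 200000 nM in this assay, at which 3 of the 3 values shown sit. Compound 4 `O=C(O)c1cccc(-c2ccc(/C=C3\S/C(=N\c4ccc(Cl)cc4)N(c4ncccc4F)C3=O)o2)c1` is not yet measured; it differs from compound 3 by fluoro in place of hydrogen on an aromatic carbon, the same kind of change, but set on a six-membered aromatic ring with one nitrogen, ortho to a large group and two atoms from the ring nitrogen, rather than on a ring of carbon only, para to a large group. Compound 4 is expected to give about 250000 nM in this assay, a step that the limit leaves unreadable from compound 3 to compound 4 from its parent. This expectation rests on compound 3 giving only a limit, > 200000 nM, and on (the limit of > 200000 nM in this assay, at which 3 of the 3 values shown sit).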

Compound 4, half-maximal cytotoxic concentration: > 200000 nM
Compound 4: only a limit was reported; the forecaster's own chance of this, stated with the estimate: 85%; the middle value does not contradict the limit.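

In this assay no step can be read from compound 3 to compound 4, for one reason: the limit of > 200000 nM in this assay, at which 4 of the 4 values shown sit. The compounds shown leave open whether going from pyridin-2-yl to 3-fluoropyridin-2-yl changes tolerance at all, since none of the four reaches a measurable cytotoxic concentration.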